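Cyclohexyl for Cyclopentyl: A Single Ring Change

A few compounds are considered here, and "the series" means these few. Any claim that something is new, unique, unknown or untested is made for them only; others in the source may bear on it.

Of the compounds shown here, three have so far been tested in a functional assay for inhibition, with Rattus norvegicus as the target; on this read-out lower numbers stand for stronger inhibition and higher numbers for weaker inhibition. Compound 1 `CC(/N=c1\c(O)c(O)\c1=N/c1cccnc1O)C(C)(C)C` reads > 30000 nM, which is a limit of the assay and not a number. Compound 2 `COc1cc(/N=c2\c(O)c(O)\c2=N/C(C)C(C)(C)C)c2ncccc2c1` reads > 30000 nM, which is likewise a limit. Among the measured compounds shown here, compound 3 `N#Cc1ccc(Nc2c(NC3CCCC3)c(=O)c2=O)cc1` gives 11500 nM, the only true number in this assay so far.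

Compound 4 `N#Cc1ccc(Nc2c(NC3CCCCC3)c(=O)c2=O)cc1` keeps the rest of compound 3 and carries cyclohexyl in place of cyclopentyl on a nitrogen on an aromatic ring. For the measured compounds named here, no measured pair of compounds differs in just one place, so the data do not show how large such a step tends to be. The expectation rests on compound 3 at 11500 nM alone, and no change beyond the scatter is expected in this assay, in either direction. A reading that gives only the limit of the assay remains possible. The expected step runs a 1.2-fold lower number from compound 3 to compound 4 (0.06 log units; within the scatter). For compound 4 the estimated value is 10000 nM, with an expected range from 3500 nM to 30000 nM.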

Compound 4, half-maximal inhibitory concentration: > 30000 nM
Compound 4: only a limit was reported (the forecaster's own chance of this, stated with the estimate: 25%); middle value at least 3.0-fold (0.47 log units) away from the limit.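

In this assay, the swap of cyclopentyl for cyclohexyl on a nitrogen on an aromatic ring gives the first single-place comparison, and the result is an at least 2.6-fold higher number from compound 3 to compound 4 (0.41 log units; beyond the scatter). Compound 4 reads > 30000 nM, which is a limit of the assay and not a number, so the step has a lower bound but no known full size. The read-out at this position therefore changes with this one ring swap, yet compound 3 remains the only compound with a true number, and the result reaches a ceiling shared by most of the series: the limit of > 30000 nM in this assay, at which 3 of the 4 values shown sit.

The compounds shown leave open whether a smaller ring such as cyclobutyl, or an open chain such as isopropyl, would give a lower number than compound 3. They also leave open whether a tetrahydropyranyl ring, with an oxygen in the ring, would read differently from cyclohexyl.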